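The compounds below may be only part of what the source reports. "The series", "measured", "known", "first", "only" and "open" are said of these compounds alone.

Measured compounds:
compound 1 `Cc1cc(SC(C)C)c(S(C)(=O)=O)cc1C(=O)N=C(N)N`, 12 nM
compound 2 `Cc1cc(N2CCC(N)CC2)c(S(C)(=O)=O)cc1C(=O)N=C(N)N`, 9.8 nM
compound 3 `Cc1cc(-n2ccnc2C)c(S(C)(=O)=O)cc1C(=O)N=C(N)N`, 29 nM

These values come from a functional assay for inhibition of sodium/hydrogen exchanger (Oryctolagus cuniculus); on this read-out lower numbers stand for stronger inhibition and higher numbers for weaker inhibition. Compound 3 gives the highest number of the three: a 2.4-fold higher number from compound 1 to compound 3 (0.38 log units; beyond the scatter) and a 3.0-fold higher number from compound 2 to compound 3 (0.47 log units; beyond the scatter). Compound 4 `Cc1cc(Oc2cncc(Cl)c2)c(S(C)(=O)=O)cc1C(=O)N=C(N)N` has not been measured; it differs from compound 3 in one place: (5-chloropyridin-3-yl)oxy in place of 2-methyl-1H-imidazol-1-yl on an aromatic carbon. Within the data shown here, no measured step swaps 2-methyl-1H-imidazol-1-yl for (5-chloropyridin-3-yl)oxy, so the two steps above are the only guide, and in both the compound carrying another group in that place gave a modestly lower number than compound 3. A modest lowering is therefore expected in this assay, a 1.9-fold lower number from compound 3 to compound 4 (0.29 log units; within the scatter), with little certainty about its size. Compound 4 is estimated at 15 nM, within a range from 5 nM to 45 nM.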

Compound 4, half-maximal inhibitory concentration: 14 nM
Compound 4: middle estimate off by 1.1-fold (0.03 log units), on the high side, within the range that was stated.
By their numbers in this assay, from the lowest: compounds 2, 1 and 4 (each within the scatter of the next); then compound 3.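

The (5-chloropyridin-3-yl)oxy group shows that this place, ortho to the methylsulfonyl group, accepts a larger group linked through oxygen: in this assay the swap gives a 2.1-fold lower number from compound 3 to compound 4 (0.32 log units; beyond the scatter) and no loss. Compound 4 also sits within the scatter of both other compounds, with a 1.4-fold higher number from compound 2 to compound 4 (0.15 log units; within the scatter) and with a 1.2-fold higher number from compound 1 to compound 4 (0.07 log units; within the scatter) as well. Thus only compound 3 stands apart, and nothing measured here explains it.

On these data alone, it remains open whether a plain phenoxy group, lacking the ring nitrogen and chlorine, would give a similar number. The effect of a carboxylic acid here is also unknown.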